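The source may report more compounds than this note shows. Statements on the series, on what has been measured and on what is new or still open speak of the compounds shown alone.

Compounds measured in a functional assay on HCC827 cells (Homo sapiens) for inhibition, read by MTT assay, with a stated time of 48 h, tested at 10 uM; on this read-out lower numbers stand for less inhibition and higher numbers for more inhibition at the one concentration tested (going by the name of the read-out):
compound 1 `COc1cc(Br)ccc1Nc1cc(NC(=O)Nc2c(Cl)cccc2Cl)ncn1` gives 42.7% in this assay
compound 2 `COc1ccc(Nc2cc(NC(=O)Nc3c(Cl)cccc3Cl)ncn2)cc1C` gives 63.1% in this assay
compound 3 `O=C(Nc1cc(Nc2ccc(F)c(Cl)c2)ncn1)Nc1c(Cl)cccc1Cl` gives 53.7% in this assay

Compound 3 sits second highest of the three: the gap to compound 2, a number 9.4 percentage points lower from compound 2 to compound 3 (within the scatter), is within the scatter, while the gap from compound 1, a number 11 percentage points higher from compound 1 to compound 3 (beyond the scatter), is beyond it. Compound 4 `CCc1ccc(Nc2cc(NC(=O)Nc3c(Cl)cccc3Cl)ncn2)cc1` differs from compound 3 by 4-ethylphenyl in place of 3-chloro-4-fluorophenyl on a nitrogen on an aromatic ring. All three measured steps change the same group on the same nitrogen and so bear on this one: a number 20.4 percentage points higher from compound 1 to compound 2 (beyond the scatter) and a number 11 percentage points higher from compound 1 to compound 3 (beyond the scatter) were modest, a number 9.4 percentage points lower from compound 2 to compound 3 (within the scatter) was within scatter. The whole spread among the three measured compounds is narrow, so for compound 4 a step within the scatter is expected, a number 1.3 percentage points higher from compound 3 to compound 4 (within the scatter). Compound 4 is estimated at 55%, between 38% and 70%.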

Compound 4, a percentage reported as inhibition, at one concentration (the size of the read-out at that concentration, not a potency): 58%
Beside the measured number, compound 4's estimate is 3 percentage points below it, and the stated range covers the measured number.
By their numbers in this assay, from the lowest: compound 1; then compounds 3, 4 and 2 (each within the scatter of the next).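

In this assay, an all-carbon 4-ethylphenyl on this nitrogen reads the same as the 3-chloro-4-fluorophenyl carrying chlorine and fluorine (a number 4.3 percentage points higher from compound 3 to compound 4 (within the scatter)) and the 4-methoxy-3-methylphenyl (a number 5.1 percentage points lower from compound 2 to compound 4 (within the scatter)). Three differently substituted groups therefore cannot be told apart here, while 4-bromo-2-methoxyphenyl stays set apart (a number 15.3 percentage points higher from compound 1 to compound 4 (beyond the scatter)). Nothing given here explains that separation. Still open, from the compounds shown here alone, is whether an amine, a carboxylic acid or a longer chain on this phenyl ring would leave this narrow band of values.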